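Swapping the Imidazole for a Trimethylpyrazole

The source may report more compounds than this note shows. Statements on the series, on what has been measured and on what is new or still open speak of the compounds shown alone.

Compound 1 `Cc1cc(C)c(-c2ncc[nH]2)cc1NC(=O)c1ccc(OCc2ccccn2)cc1` was tested in a physicochemical assay for solubility, at pH 7.4 (a lower number here means a less soluble compound, a higher number a more soluble compound), where compound 1 gives 2000 nM. Among the three measured compounds this is the second highest number: compound 2 `Cc1cc(F)c(-c2ncc[nH]2)cc1NC(=O)c1ccc(OCc2ccccn2)cc1` gives 1000 nM, and compound 3 `Cc1ccc(-c2ncc[nH]2)c(C)c1NC(=O)c1ccc(OCc2ccccn2)cc1` gives 69000 nM. For the measured compounds named here, the only single-place step among them, a 2.0-fold lower number from compound 1 to compound 2 (0.30 log units; within the scatter), lies within the scatter. Compound 4 `Cc1cc(C)c(-c2c(C)nn(C)c2C)cc1NC(=O)c1ccc(OCc2ccccn2)cc1` differs from compound 1 in one place: 1,3,5-trimethyl-1H-pyrazol-4-yl in place of 1H-imidazol-2-yl on an aromatic carbon. Going by the values given here, no measured step touches this group, so the direction of any change is open. Lacking a guiding step, the estimate is kept near the starting value with a wide range, and the expected step is a 1.3-fold lower number from compound 1 to compound 4 (0.12 log units; within the scatter). For compound 4 the expected value in this assay is 1500 nM, between 300 nM and 8000 nM.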

Compound 4, solubility: 35000 nM
The estimate for compound 4 lay 23-fold (1.37 log units) below the measured number; measured number outside the range, above it.
By their numbers in this assay, from the lowest: compounds 2 and 1 (each within the scatter of the next); then compounds 4 and 3 (each within the scatter of the next).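

For the compounds shown here, this position responds strongly in this assay: 1,3,5-trimethyl-1H-pyrazol-4-yl in place of 1H-imidazol-2-yl gives an 18-fold higher number from compound 1 to compound 4 (1.24 log units; beyond the scatter), while the one earlier step, a 2.0-fold lower number from compound 1 to compound 2 (0.30 log units; within the scatter), did not exceed the scatter. The change swaps a ring carrying a hydrogen-bond donor for one with none, yet nothing measured here ties the higher number to this or any other difference between the two groups.

The compounds shown do not separate the effect of the three methyl groups from that of the ring swap itself. On these data alone, how a plain 1H-pyrazol-4-yl group, or a ring carrying an amine, would read in this assay remains open.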